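The compounds below may be only part of what the source reports. "The series", "measured", "known", "first", "only" and "open" are said of these compounds alone.

Compound 1 `Cc1ccc(-c2nn(-c3ccccc3)cc2C(Nc2nc3cc(C)c(C)cc3s2)c2c(O)ccc3ccccc23)cc1`, compound 2 `Cc1cc2nc(NC(c3cn(-c4ccccc4)nc3-c3ccc([N+](=O)[O-])cc3)c3c(O)ccc4ccccc34)sc2cc1C` and compound 3 `Cc1ccc(-c2nn(-c3ccccc3)cc2C(Nc2nc3ccccc3s2)c2c(O)ccc3ccccc23)cc1` share one core and were all tested in a functional assay on A549 cells (Homo sapiens) for antiproliferative activity, read by MTT assay, with a stated time of 48 h; a higher number here means a weaker inhibitor, a lower number a stronger inhibitor. Compound 1 gives 31200 nM, compound 2 gives 41900 nM and compound 3 gives 57400 nM. Compound 2 thus stands second highest of the three numbers, yet neither gap around it is meaningful: there is a 1.3-fold higher number from compound 1 to compound 2 (0.13 log units; within the scatter), and the values of compound 2 and compound 3 lie equally close together. Compound 4 `O=[N+]([O-])c1ccc(-c2nn(-c3ccccc3)cc2C(Nc2nc3ccc(Cl)cc3s2)c2c(O)ccc3ccccc23)cc1` has not been measured; it differs from compound 2 by 6-chloro-1,3-benzothiazol-2-yl in place of 5,6-dimethyl-1,3-benzothiazol-2-yl on an amine nitrogen. Among the measured compounds shown here, the one measured step that touches the same part of the core is a 1.8-fold higher number from compound 1 to compound 3 (0.26 log units; within the scatter), where the 5,6-dimethyl-1,3-benzothiazol-2-yl group was likewise exchanged, and it stayed within the scatter. For the measured compounds named here, no measured compound carries a 6-chloro-1,3-benzothiazol-2-yl group, so the expectation rests on that single step alone. The step from compound 2 to compound 4 is therefore expected to be small, a 1.2-fold higher number from compound 2 to compound 4 (0.08 log units; within the scatter), leaning toward a higher number. Compound 4 is estimated at 50000 nM in this assay, with a likely range from 20000 nM to 120000 nM.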

Compound 4, half-maximal inhibitory concentration: 57200 nM
For compound 4 the middle estimate is 1.1-fold (0.06 log units) below the measured one; the range from low to high includes it.
By their numbers in this assay, from the lowest: compounds 1, 2, 4 and 3 (each within the scatter of the next).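

With the nitro group in place, 6-chloro-1,3-benzothiazol-2-yl on the amine nitrogen gives a 1.4-fold higher number from compound 2 to compound 4 (0.14 log units; within the scatter) in this assay. The earlier exchange at this place, a 1.8-fold higher number from compound 1 to compound 3 (0.26 log units; within the scatter), involved only the 1,3-benzothiazol-2-yl group without substituents and a compound carrying methyl rather than nitro, so a chlorine-bearing group and a second version of the core now also stay within the scatter. No evidence is available to explain why this exchange leaves the number so little changed.

From the compounds shown here alone, it remains open whether a carboxylic acid or an amine on the 1,3-benzothiazol-2-yl group would give a step beyond the scatter. Going by these compounds, it is also open whether replacing the whole group with a simple phenyl ring on the amine nitrogen would do so.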